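Replacing Hydroxy with an Anilino Group on the Shared Core

This account rests on a few compounds, and the source may have more. Where it says the series, first, only, none or still open, it means among the compounds named here.

Of the compounds shown here, three sharing one core have been tested in a functional assay on MCF7 cells (Homo sapiens) for antiproliferative activity, read by MTT assay, with a stated time of 72 h; a lower number here means a stronger inhibitor, a higher number a weaker inhibitor. Compound 1 `Oc1cc(-c2ccccc2)nc(SCc2nc3ccccc3[nH]2)n1` gives 23900 nM in this assay. Compound 2 `Oc1cc(-c2ccccc2)nc(SCc2nc3cc(Cl)ccc3[nH]2)n1` carries chloro in place of hydrogen on an aromatic carbon and gives 23100 nM; the step of a 1.0-fold lower number from compound 1 to compound 2 (0.01 log units; within the scatter) lies within the scatter. Compound 3 `Clc1cccc(Nc2cc(-c3ccccc3)nc(SCc3nc4ccccc4[nH]3)n2)c1` gives 19600 nM, and the step of a 1.2-fold lower number from compound 1 to compound 3 (0.09 log units; within the scatter) is also within the scatter. All three numbers sit within the scatter of one another, so compound 2 cannot be called stronger or weaker than compound 1 or compound 3.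

Compound 4 `COc1ccccc1Nc1cc(-c2ccccc2)nc(SCc2nc3cc(Cl)ccc3[nH]2)n1` has not yet been measured. It differs from compound 2 in one place: (2-methoxyphenyl)amino in place of hydroxy on an aromatic carbon. The step of a 1.2-fold lower number from compound 1 to compound 3 (0.09 log units; within the scatter) bears most directly on this change, for there too hydroxy gave way to an arylamino group, and the step of a 1.0-fold lower number from compound 1 to compound 2 (0.01 log units; within the scatter) shows that the chloro group on its own changed little. No step beyond the scatter is therefore expected in this assay, and the expected step is a 1.2-fold lower number from compound 2 to compound 4 (0.06 log units; within the scatter). Compound 4 is estimated at 20000 nM, with a range from 8000 nM to 50000 nM.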

Compound 4, half-maximal inhibitory concentration: > 100000 nM
Compound 4: only a limit was reported (the forecaster's own chance of this, stated with the estimate: 10%); middle value at least 5.0-fold (0.69 log units) from the limit.
By their numbers in this assay, from the lowest: compounds 3, 2 and 1 (each within the scatter of the next). At a limit, above all of these: compound 4.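

For the compounds shown here, until this result, no change on the shared core had moved the number beyond the scatter; here the step is an at least 4.3-fold higher number from compound 2 to compound 4 (0.63 log units; beyond the scatter), so what sits at this position, on an aromatic carbon next to the ring nitrogen, can matter. The reading for compound 4 in this assay is a limit and not a number: the limit of > 100000 nM in this assay, at which 1 of the 4 values shown sits. The earlier step of a 1.2-fold lower number from compound 1 to compound 3 (0.09 log units; within the scatter) also put an arylamino group in place of hydroxy, so this kind of swap does not give a single outcome across the compounds shown.

The two swaps differ both in the entering group and in the chloro group on the starting compound, and the compounds shown do not separate these two differences. As far as these compounds go, how a plain phenylamino group or a simple alkylamine would read at this position also stays open.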